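The source may hold more compounds than are shown below. What is called first, only, known or untested is meant among the compounds shown, and "the series" means these compounds.

Values in a functional assay on A549 cells (Homo sapiens) for cytotoxicity, read by MTT assay, with a stated time of 72 h; a lower number here means a stronger inhibitor, a higher number a weaker inhibitor:
compound 1 `CNC(=O)c1cc(Oc2ccc(NC(=O)c3cc(-c4ccc(C)cc4)ncn3)cc2)ccn1`: > 100000 nM
compound 2 `CCc1ccc(-c2cc(C(=O)Nc3ccc(Oc4ccnc(C(=O)NC)c4)cc3)ncn2)cc1`: 13300 nM
compound 3 `CNC(=O)c1cc(Oc2ccc(NC(=O)c3cc(-c4ccc(Cl)cc4)ncn3)cc2)ccn1`: > 100000 nM

The two entries with a sign are limits, not numbers. Compound 3 stands at the limit of > 100000 nM in this assay, at which 2 of the 3 values shown sit. Compound 4 `CNC(=O)c1cc(Oc2ccc(NC(=O)c3cc(-c4ccccc4)ncn3)cc2)ccn1` differs from compound 3 in one place: hydrogen in place of chloro on an aromatic carbon, which is hydrogen in place of chloro on an aromatic carbon, or 4-chlorophenyl to phenyl.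

Among the measured compounds shown here, three measured steps bear on this change. The closest, a step that the two limits leave unreadable from compound 1 to compound 3, also changes the group at this place. Two further steps involve the ethyl group: an at least 7.5-fold lower number from compound 1 to compound 2 (0.87 log units; beyond the scatter) and an at least 7.5-fold higher number from compound 2 to compound 3 (0.87 log units; beyond the scatter). Among these three compounds, only the ethyl compound gives a number. Compound 4 lacks the ethyl group, so no step beyond the scatter in this assay is expected. If a step can be read at all, a lower number is the expected direction. The expected step is an at least 1.4-fold lower number from compound 3 to compound 4 (0.15 log units; that floor lies within the scatter). The estimate for compound 4 is 70000 nM, with an expected range of 15000 nM to 150000 nM.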

Compound 4, half-maximal inhibitory concentration: 27100 nM
Beside the measured number, compound 4's estimate is 2.6-fold (0.41 log units) above it; low and high end bracket the measured number.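

In this assay, hydrogen at this place on the aromatic ring gives a readable number, so a measured value no longer depends on the ethyl group alone: an at least 3.6-fold lower number from compound 3 to compound 4 (0.56 log units; beyond the scatter) and an at least 3.6-fold lower number from compound 1 to compound 4 (0.56 log units; beyond the scatter). Ethyl still holds a modest edge over hydrogen, a 2.0-fold higher number from compound 2 to compound 4 (0.31 log units; beyond the scatter), so the number does not move in one direction from hydrogen through methyl to ethyl. Compound 1 and compound 3 remain limits rather than numbers, and the step between them cannot be read: the limit of > 100000 nM in this assay, at which 2 of the 4 values shown sit.

On these data alone, whether a longer chain such as propyl or butyl, or an amine or a carboxylic acid, would continue or break this uneven pattern stays open. Also open, as far as these compounds go, is whether any group at this place improves on compound 2, at 13300 nM.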